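The compounds below may be only part of what the source reports. "The series", "measured", "known", "first", "only" and "open" are said of these compounds alone.

Of the compounds shown here, two have been measured in a functional assay on the whole organism (strain Wistar albino) for inhibition, with Rattus norvegicus as the target, read by paw edema, with stated times of 1 h and 2 h, at a dose of 40 mg/kg by the oral route (on this read-out higher numbers stand for more inhibition at the one dose given (going by the name of the read-out) and lower numbers for less inhibition), so far. Compound 1 `COc1ccc(N2C(=O)CSC2c2sc(Cc3ccc(Cl)cc3)nc2C)cc1` gives 28.6%, and compound 2 `Cc1nc(-c2ccc(Cl)cc2)sc1C1SCC(=O)N1c1ccc(Cl)cc1` gives 45.7%. Compound 2 thus stands highest of the two numbers, and its lead over compound 1 lies beyond the usual scatter of this kind of measurement. Compound 3 `COc1ccc(N2C(=O)CSC2c2sc(-c3ccc(Cl)cc3)nc2C)cc1` has not yet been measured. It differs from compound 2 in one place: methoxy in place of chloro on an aromatic carbon. Among the compounds with values here, no pair of measured compounds shows this change alone, so the size of the step has to be estimated from what the two measured values show. Compound 1 also carries a methoxy on that ring and sits lower, but it differs from compound 3 elsewhere as well. For compound 3 a modest fall is expected, a number 7.7 percentage points lower from compound 2 to compound 3 (within the scatter), within the scatter. Compound 3 is therefore expected to give about 38%, between 25% and 50%.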

Compound 3, a percentage reported as inhibition, in the whole organism at one dose (the size of the read-out at that dose, not a potency): 80.7%
For compound 3 the middle estimate is 42.7 percentage points below the measured one; measured number above the stated range.
By their numbers in this assay, from the lowest: compound 1; then compound 2; then compound 3.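

In this assay, within the data shown here, methoxy in place of chloro on the aromatic carbon para to a large group gives a number 35 percentage points higher from compound 2 to compound 3 (beyond the scatter), the first reading of this change on its own, and it shows that this position strongly affects the read-out. With the methoxy held fixed, 4-chlorophenyl in place of 4-chlorobenzyl gives a number 52.1 percentage points higher from compound 1 to compound 3 (beyond the scatter), so the low number of compound 1 goes with its benzyl group and not with its methoxy, which the earlier comparison of compound 1 and compound 2, differing in more than one place, could not separate. Nothing measured here accounts for either step.

The compounds shown leave open how a hydroxyl, an amine or a longer ether such as ethoxy would compare with methoxy at this position. They also leave open whether chloro to methoxy gives a step of similar size when the 4-chlorobenzyl group is present.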